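The source may report more compounds than this note shows. Statements on the series, on what has been measured and on what is new or still open speak of the compounds shown alone.

Measured compounds in an in vitro ADME assay on the whole organism (microsomes, liver, Mus musculus) for metabolic stability, read by LC-MS, with a stated time of 24 h, at a dose of 5 mg/kg by the intravenous route; a lower number here means that the compound disappears faster, a higher number that the compound lasts longer:
compound 1, `O=[N+]([O-])c1cn2c(n1)OC[C@@H](NCc1ccc(OC(F)(F)F)cc1Cl)C2` — 0.332 h
compound 2, `CC(C)N(Cc1ccc(OC(F)(F)F)cc1)[C@@H]1COc2nc([N+](=O)[O-])cn2C1` — 0.0533 h

Compound 1 stands highest of the two numbers in this assay. The nearest, compound 2, gives a lower half-life, and the gap between the two lies beyond the usual scatter. Going by the values given here, the two compounds differ in more than one place, so no single-change step is available from them.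

Compound 3, `O=[N+]([O-])c1cn2c(n1)OC[C@@H](NCc1ccc(OC(F)(F)F)cc1O)C2`, is the next compound for this assay. It differs from compound 1 by hydroxy in place of chloro on an aromatic carbon. Among the compounds with values here, no measured pair shows this particular change, so the expectation rests on compound 1 alone. From compound 1 to compound 3 the expected step is a 1.3-fold lower number from compound 1 to compound 3 (0.12 log units; within the scatter), a small downward movement that stays within the scatter. Compound 3 is estimated at 0.25 h, with a range from 0.08 h to 0.8 h.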

Compound 3, half-life: 0.238 h
Estimate against measurement, compound 3: 1.1-fold (0.02 log units) above; measured number inside the range.
By their numbers in this assay, from the lowest: compound 2; then compounds 3 and 1 (each within the scatter of the next).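

In this assay, exchanging chloro for hydroxy, ortho to a large group and meta to a trifluoromethoxy group, gives a 1.4-fold lower number from compound 1 to compound 3 (0.14 log units; within the scatter), so the two half-lives cannot be told apart. Going by these compounds alone, this is the first single-place step, and it shows that this exchange, which adds a hydrogen-bond donor and a hydrogen-bond acceptor, leaves the half-life within the scatter at this position. The data shown offer no measured basis for explaining this outcome.

A single pair speaks only for chloro and hydroxy at this position, so it does not show whether the result extends to other groups. Open, from the compounds shown here alone, are the half-lives with methoxy, an amine or a nitrile there, or with plain hydrogen in place of either group.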